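Amide nitrogen methylation in the quinoline-free analogue series

A few compounds are considered here, and "the series" means these few. Any claim that something is new, unique, unknown or untested is made for them only; others in the source may bear on it.

Three compounds have numbers in an assay on CHO cells for displacement of a labelled ligand from Substance-P receptor (Homo sapiens), with a stated time of 90 min; a higher number here means a weaker inhibitor, a lower number a stronger inhibitor. Compound 1 `Cc1nc2ccccc2c(-c2ccccc2)c1C(=O)N(C)Cc1cc(C(F)(F)F)cc(C(F)(F)F)c1` gives 19 nM. Compound 2 `Cc1nccc(-c2ccccc2)c1C(=O)N(C)Cc1cc(C(F)(F)F)cc(C(F)(F)F)c1` gives 98 nM. Compound 3 `Cc1nc(Cl)cc(-c2ccccc2)c1C(=O)NCc1cc(C(F)(F)F)cc(C(F)(F)F)c1` gives 270 nM, the highest of the three numbers; its gap to compound 2 and its gap to compound 1 both lie beyond the scatter. Within the data shown here, compound 1 and compound 2 differ from compound 3 in more than one place, so no single step between measured compounds is available.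

Compound 4 `Cc1nc(Cl)cc(-c2ccccc2)c1C(=O)N(C)Cc1cc(C(F)(F)F)cc(C(F)(F)F)c1` differs from compound 3 only by methyl in place of hydrogen on an amide-type nitrogen. Compound 1 and compound 2 both carry a methyl on the amide nitrogen and both sit at lower numbers than compound 3, but their other differences leave the contribution of the methyl alone unresolved. A moderate step downward, beyond the scatter but short of the gap to compound 1, is expected; the estimated step of a 3.4-fold lower number from compound 3 to compound 4 (0.53 log units; beyond the scatter) carries that expectation. For compound 4 the value in this assay is estimated at 80 nM, within 25 nM to 250 nM.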

Compound 4, half-maximal inhibitory concentration: 91 nM
Beside the measured number, compound 4's estimate is 1.1-fold (0.06 log units) below it, and the stated range covers the measured number.
By their numbers in this assay, from the lowest: compound 1; then compounds 4 and 2 (each within the scatter of the next); then compound 3.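

In this assay, methyl in place of hydrogen on the amide-type nitrogen gives a 3.0-fold lower number from compound 3 to compound 4 (0.47 log units; beyond the scatter), which isolates this change at this position, something compounds 1 and 2 could not do with their other differences from compound 3. With that methyl present, chloro in place of hydrogen on an aromatic carbon gives a 1.1-fold lower number from compound 2 to compound 4 (0.03 log units; within the scatter), so compound 2 and compound 4 cannot be told apart in this assay. No supporting data bear on why the methyl step occurs.

From the compounds shown here alone, the methyl step rests on one matched pair, so its size on the core of compound 1 or without the chloro remains open. Also open, going by these compounds, is how ethyl, a longer chain or a carboxylic acid on the same nitrogen would compare with methyl.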